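From compound 3 to compound 4: one group swap

A few compounds are considered here, and "the series" means these few. Any claim that something is new, unique, unknown or untested is made for them only; others in the source may bear on it.

Values so far in a functional assay on HeLa cells (Homo sapiens) for cytotoxicity, read by MTT assay, with a stated time of 48 h (on this read-out higher numbers stand for weaker inhibition and lower numbers for stronger inhibition), for the measured compounds:
compound 1 `CC1(C)CCCC2=CC=C(C=O)CC[C@]21C` gives 163000 nM
compound 2 `C=C1CCC[C@]2(C)CCC(c3cn(-c4ccc(OC)cc4)nn3)=CC[C@@]12C` gives 43600 nM
compound 3 `C=C1CCC[C@]2(C)CCC(c3cn(-c4cccc([N+](=O)[O-])c4)nn3)=CC[C@@]12C` gives 31900 nM

Compound 3 stands with compound 2 at the low end of these numbers, the two within the scatter of each other. Compound 1 lies furthest from compound 3, beyond the scatter. Compound 4 `C=C1CCC[C@]2(C)CCC(c3cn(-c4ccccc4C(C)=O)nn3)=CC[C@@]12C` carries 2-acetylphenyl in place of 3-nitrophenyl on an aromatic nitrogen, and 2-acetylphenyl in place of 3-nitrophenyl on an aromatic nitrogen gives the counted difference. Among the measured compounds shown here, the one measured swap at this place is a 1.4-fold lower number from compound 2 to compound 3 (0.14 log units; within the scatter) and it stays within the scatter. For the measured compounds named here, no measured compound carries 2-acetylphenyl, so this single step is a thin guide. On the strength of that step from compound 2 to compound 3, no step beyond the scatter is expected in this assay in either direction. The estimated step is a 1.1-fold higher number from compound 3 to compound 4 (0.04 log units; within the scatter) and it remains an expectation. Compound 4 is expected at 35000 nM (estimated range 15000 nM to 80000 nM).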

Compound 4, half-maximal inhibitory concentration: 55700 nM
Beside the measured number, compound 4's estimate is 1.6-fold (0.20 log units) below it; the range from low to high includes it.
By their numbers in this assay, from the lowest: compounds 3, 2 and 4 (each within the scatter of the next); then compound 1.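

In this assay, among the compounds shown here, the aryl group on an aromatic nitrogen now has two further readable steps, a 1.7-fold higher number from compound 3 to compound 4 (0.24 log units; within the scatter) and a 1.3-fold higher number from compound 2 to compound 4 (0.11 log units; within the scatter) and both stay within the scatter, as did the one earlier step at this position. With 2-acetylphenyl added to 4-methoxyphenyl and 3-nitrophenyl, the three groups at this place are not separated by this read-out, even though 2-acetylphenyl brings a carbonyl where 3-nitrophenyl had a nitro group and has one hydrogen-bond acceptor where 3-nitrophenyl has two. No supporting measurement bears on this result, so the data give no account of it.

Going by these compounds, whether any group at this place can move the number beyond the scatter remains open. An aminophenyl or carboxyphenyl group, or a longer alkyl chain in place of the aryl ring, would put that to the test.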